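A few compounds are considered here, and "the series" means these few. Any claim that something is new, unique, unknown or untested is made for them only; others in the source may bear on it.

Measured compounds:
- compound 1, `CC1CCC(Nc2nc(C(F)(F)F)ccc2CNC(=O)C(C)c2ccc(NS(C)(=O)=O)c(F)c2)CC1`, giving 27.2 nM
- compound 2, `CC(C(=O)NCc1ccc(C(F)(F)F)nc1N(C)C)c1ccc(NS(C)(=O)=O)c(F)c1`, giving 19.1 nM
- compound 3, `CCCCN(C)c1nc(C(F)(F)F)ccc1CNC(=O)C(C)c1ccc(NS(C)(=O)=O)c(F)c1`, giving 0.8 nM

All three compounds share one core and differ only in the amine attached to an aromatic carbon of the pyridine-type ring. In a functional assay on CHO-K1 cells for antagonist activity at transient receptor potential cation channel subfamily V member 1 (Homo sapiens), read by FLIPR (on this read-out higher numbers stand for weaker inhibition and lower numbers for stronger inhibition), compound 3 has the lowest number of the three: its nearest neighbour is compound 2, with a 24-fold lower number from compound 2 to compound 3 (1.38 log units; beyond the scatter), and its furthest is compound 1, with a 34-fold lower number from compound 1 to compound 3 (1.53 log units; beyond the scatter). Between compound 1 and compound 2 the gap is only a 1.4-fold lower number from compound 1 to compound 2 (0.15 log units; within the scatter).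

Compound 4, `CC(C(=O)NCc1ccc(C(F)(F)F)nc1N1CCC(c2ccccc2)CC1)c1ccc(NS(C)(=O)=O)c(F)c1`, has not yet been measured. It differs from compound 3 in one place: 4-phenylpiperidin-1-yl in place of butyl(methyl)amino on an aromatic carbon. Among the compounds with values here, the steps that bear on this are the two large ones leading to compound 3. Both show that the butyl(methyl)amino group of compound 3 stands well apart from a smaller amine and from a ring-bearing amine. Swapping it for a ring group of roughly double its size is therefore expected to give a higher number, of moderate size, a 7.5-fold higher number from compound 3 to compound 4 (0.88 log units; beyond the scatter). The estimate for compound 4 in this assay is 6 nM, with a range from 1 nM to 40 nM.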

Compound 4, inhibition constant: 0.6 nM
Estimate against measurement, compound 4: 10-fold (1.00 log units) above, outside the stated range (below it).
By their numbers in this assay, from the lowest: compounds 4 and 3 (each within the scatter of the next); then compounds 2 and 1 (each within the scatter of the next).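

In this assay, the change from butyl(methyl)amino to 4-phenylpiperidin-1-yl gives a 1.3-fold lower number from compound 3 to compound 4 (0.12 log units; within the scatter) and so makes no measurable difference, even though the entering group has more heavy atoms and brings two rings. This position therefore accepts both an open chain and a much larger two-ring group in the same low range, and the ring-bearing amine of compound 4 stands well apart from the other two amines, with a 32-fold lower number from compound 2 to compound 4 (1.50 log units; beyond the scatter) and a 45-fold lower number from compound 1 to compound 4 (1.66 log units; beyond the scatter) in the same assay. Having a ring on the amine does not by itself decide the outcome, as compound 1 also carries one and gives a much higher number; nothing measured here explains these differences.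

Going by these compounds, it remains open whether plain piperidin-1-yl, without the phenyl ring, would stay in this low range. A longer chain, such as hexyl(methyl)amino, is also untested by the compounds shown.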